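The source may hold more compounds than are shown below. What is called first, only, known or untested is meant among the compounds shown, and "the series" means these compounds.

In a functional assay on DU-145 cells (Homo sapiens) for cytotoxicity (a higher number here means a weaker inhibitor of growth, a lower number a stronger inhibitor of growth), compound 1 (`COc1ccc(C2=C(c3ccc(SC)cc3)CC3CCCN3C2=O)cc1Br`) gives 900 nM as its reading. Compound 2 (`CSc1ccc(C2=C(c3ccc(F)c(F)c3)C(=O)N3CCCC3C2)cc1`) gives 500 nM and compound 3 (`CSc1ccc(C2=C(c3ccc(C)c(C)c3)C(=O)N3CCCC3C2)cc1`) gives 500 nM in the same test, so compound 3 sits level with compound 2 and within the scatter of compound 1.

Compound 4 (`CSc1ccc(C2=C(c3ccc(F)c(C)c3)C(=O)N3CCCC3C2)cc1`) departs from compound 3 at a single spot: fluoro in place of methyl on an aromatic carbon in this case, fluoro in place of methyl on an aromatic carbon, ortho to a methyl group and para to a large group. Put another way, 3,4-dimethylphenyl becomes 4-fluoro-3-methylphenyl.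

Among the measured compounds shown here, three measured steps bear on this swap, and all of them exchange this same substituted phenyl group. The closest is no change at the digits printed from compound 2 to compound 3 (within the scatter), a swap of 3,4-difluorophenyl for 3,4-dimethylphenyl, and compound 4 carries one fluoro and one methyl, a mix of those two patterns. The other two, a 1.8-fold lower number from compound 1 to compound 2 (0.26 log units; within the scatter) and a 1.8-fold lower number from compound 1 to compound 3 (0.26 log units; within the scatter), start from 3-bromo-4-methoxyphenyl, a more different group, and they also stay within the scatter.

No step beyond the scatter is therefore expected in this assay for this swap. The estimated step is no change at the digits printed from compound 3 to compound 4 (within the scatter) in this test. Compound 4 is expected at 500 nM in this test, with an estimated range from 270 nM to 950 nM for repeat readings.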

Compound 4, concentration for 50% growth inhibition: 500 nM
Compound 4: the middle estimate sits on the measured number at the digits printed; the range from low to high includes it.
By their numbers in this assay, from the lowest: compounds 2, 3, 4 and 1 (each within the scatter of the next).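

Changing one substituent at a time adds something that compound 2 and compound 3, which differ at two ring positions, could not show. In this assay, fluoro in place of methyl on this aromatic carbon, ortho to a methyl group and para to a large group, gives (no change at the digits printed from compound 3 to compound 4 (within the scatter)), and methyl in place of fluoro on the neighbouring substituted carbon of 3,4-difluorophenyl gives (no change at the digits printed from compound 2 to compound 4 (within the scatter)), so neither single exchange moves the reading beyond the scatter. The 4-fluoro-3-methylphenyl group also stays within the scatter of 3-bromo-4-methoxyphenyl (a 1.8-fold lower number from compound 1 to compound 4 (0.26 log units; within the scatter)), and nothing measured here explains why these groups read alike.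

These compounds leave open whether an amine, a carboxylic acid or a longer chain such as butyl on this phenyl ring would finally shift the reading beyond the scatter. Also open, going by these compounds, is how far the reading depends on the 4-methylthiophenyl group, which is the same in all four compounds.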